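A few compounds are considered here, and "the series" means these few. Any claim that something is new, unique, unknown or untested is made for them only; others in the source may bear on it.

Two compounds of this series carry a value in a functional assay on MCF7 cells (Homo sapiens) for inhibition, read by sulforhodamine B assay, with a stated time of 24 h; a lower number here means a stronger inhibitor of growth, a higher number a weaker inhibitor of growth. Compound 1 `CCOC(=O)C1=C(C)NC(=S)NC1c1cn(-c2ccccc2)nc1-c1ccccc1` gives 42000 nM. Compound 2 `CC1=C(C(=O)Nc2ccccc2Cl)C(c2cn(-c3ccccc3)nc2-c2ccccc2)NC(=S)N1` gives 68800 nM. Within the data shown here, the only measured step, a 1.6-fold higher number from compound 1 to compound 2 (0.21 log units; within the scatter), exchanged the ethoxy on the carbonyl carbon for (2-chlorophenyl)amino and moved nothing beyond the scatter. On the numbers shown compound 2 stands as one of two values that cannot be separated: the gap to compound 1 is within the scatter, so neither compound is set apart from the other.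

Compound 3 `CC1=C(C(=O)Nc2ccc([N+](=O)[O-])cc2)C(c2cn(-c3ccccc3)nc2-c2ccccc2)NC(=S)N1` keeps the (2-chlorophenyl)carbamoyl arrangement of compound 2 except for the aryl on the amide-type nitrogen: 4-nitrophenyl in place of 2-chlorophenyl on an amide-type nitrogen. Among the measured compounds shown here, no measured step touches this position; the step from compound 1 to compound 2 concerned the substituent on the carbonyl carbon and says nothing about exchanging one aryl for another on the amide-type nitrogen. For the measured compounds named here, with no step bearing on the change, no shift beyond the scatter is expected in this assay, and compound 3 is expected to sit near compound 2, a 1.0-fold higher number from compound 2 to compound 3 (0.01 log units; within the scatter). The estimate for compound 3 is 70000 nM, with a range from 30000 nM to 160000 nM.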

Compound 3, concentration for 50% growth inhibition: 41400 nM
For compound 3 the middle estimate is 1.7-fold (0.23 log units) above the measured one; the range from low to high includes it.
By their numbers in this assay, from the lowest: compounds 3, 1 and 2 (each within the scatter of the next).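

In this assay, among these compounds, the first measured change of the aryl on the amide-type nitrogen gives a 1.7-fold lower number from compound 2 to compound 3 (0.22 log units; within the scatter) and so, for this pair, exchanging 2-chlorophenyl for 4-nitrophenyl does not separate the two compounds. At the carbonyl carbon, (4-nitrophenyl)amino in place of ethoxy gives a 1.0-fold lower number from compound 1 to compound 3 (0.01 log units; within the scatter) and thus joins (2-chlorophenyl)amino as a second replacement of ethoxy that stays within the scatter, so the three values shown cannot be ranked against one another. No measurement is available that would explain why these changes leave the growth-inhibition values unseparated.

The compounds shown cover only an ethyl ester and two aryl amides on the shared core, so it remains open whether a carboxylic acid, a simple alkylamino group such as methylamino, or a cyclic amine such as morpholine on the carbonyl carbon would give a value beyond the scatter of these three. On these data alone, on the amide-type nitrogen, it also remains open whether unsubstituted phenyl, 4-methoxyphenyl or a benzyl group would separate from 2-chlorophenyl and 4-nitrophenyl.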